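Swapping the amide aryl group: a quinoline in place of a tetralin

The compounds below may be only part of what the source reports. "The series", "measured", "known", "first", "only" and "open" are said of these compounds alone.

Measured so far:
- compound 1 `CN1[C@@H]2c3[nH]c4ccccc4c3C[C@H]1[C@H](C#N)N1[C@@H](CNC(=O)c3ccc(F)cc3)c3[nH]c4ccccc4c3C[C@@H]21`: 980 nM
- compound 2 `CN1[C@@H]2c3[nH]c4ccccc4c3C[C@H]1[C@H](C#N)N1[C@@H](CNC(=O)c3cccc4c3CCCC4)c3[nH]c4ccccc4c3C[C@@H]21`: 4470 nM

Both compounds were tested in a functional assay on MCF7 cells (Homo sapiens) for cytotoxicity, read by MTT assay, with a stated time of 72 h; on this read-out lower numbers stand for stronger inhibition and higher numbers for weaker inhibition. On the numbers shown, compound 2 stands at the higher of the two, the other being compound 1; the step of a 4.6-fold higher number from compound 1 to compound 2 (0.66 log units; beyond the scatter) lies beyond the scatter and is the only comparison available.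

Compound 3 `CN1[C@@H]2c3[nH]c4ccccc4c3C[C@H]1[C@H](C#N)N1[C@@H](CNC(=O)c3ccc4ccccc4n3)c3[nH]c4ccccc4c3C[C@@H]21` differs from compound 2 in one place: quinolin-2-yl in place of 1,2,3,4-tetrahydronaphthalen-5-yl on a carbonyl carbon. Within the data shown here, the one measured step bears on it only loosely: it shows that exchanging the 4-fluorophenyl for the 1,2,3,4-tetrahydronaphthalen-5-yl weakened the compound, but no measured compound carries an aromatic ring with a hetero atom at this carbonyl, so the direction for compound 3 is uncertain.

Compound 3 is therefore expected to land near compound 2, with a wide band: an estimated 2500 nM, between 600 nM and 10000 nM, meaning an expected step of a 1.8-fold lower number from compound 2 to compound 3 (0.25 log units; within the scatter).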

Compound 3, half-maximal inhibitory concentration: 150 nM
Compound 3: the middle estimate sits 17-fold (1.22 log units) above what was measured; measured number below the stated range.
By their numbers in this assay, from the lowest: compound 3; then compound 1; then compound 2.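

In this assay, the group on the amide carbonyl proves able to move the number much further than the first pair suggested: quinolin-2-yl in place of 1,2,3,4-tetrahydronaphthalen-5-yl gives a 30-fold lower number from compound 2 to compound 3 (1.47 log units; beyond the scatter) even though both groups have the same heavy-atom count. Compound 3 also improves on the 4-fluorophenyl amide, with a 6.5-fold lower number from compound 1 to compound 3 (0.82 log units; beyond the scatter) as the step, so this position can strengthen the compound as well as weaken it. No supporting measurement here explains the improvement.

Quinolin-2-yl differs from the tetralin group in two ways, a ring nitrogen and a second aromatic ring, and these compounds cannot separate the two. Also open, on these data alone, is whether a smaller pyridin-2-yl ring, or a quinoline carrying a methoxy group or an amine, would keep the low number.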